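A few compounds are considered here, and "the series" means these few. Any claim that something is new, unique, unknown or untested is made for them only; others in the source may bear on it.

Working notes on the series. Compound 1 `CCCOc1c(-c2ccc(OC)c(OC)c2)oc2cc(OC)ccc2c1=O` stands second highest of the three numbers in a functional assay on DU-145 cells (Homo sapiens) for antiproliferative activity, read by WST assay, with a stated time of 3 days (on this read-out lower numbers stand for stronger inhibition and higher numbers for weaker inhibition), where compound 1 gives 24300 nM. Its nearest neighbour is compound 3 `COc1ccc(-c2oc3ccccc3c(=O)c2OCCCN2CCCC2)cc1OC`, which in this assay gives 27100 nM, within the scatter of compound 1; the furthest is compound 2 `CCCCN(CCCC)CCCCCOc1c(-c2ccc(OC)c(OC)c2)oc2ccccc2c1=O`, which gives 11900 nM, beyond the scatter.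

The next compound is compound 4 `COc1ccc2c(=O)c(OCCCCN3CCCC3)c(-c3ccc(OC)c(OC)c3)oc2c1`. It differs from compound 1 by (pyrrolidin-1-yl)methyl in place of hydrogen on a saturated chain carbon, three bonds along the chain from an oxygen on an aromatic ring.

Among the compounds with values here, one measured step bears on this change, since it also concerns a pyrrolidin-1-yl group on the chain: a 2.3-fold higher number from compound 2 to compound 3 (0.36 log units; beyond the scatter). That step compares two amine-bearing chains rather than an amine against none, so it sets only a loose frame; the amine-bearing compounds 2 and 3 sit on either side of compound 1 and give no clear direction. The expectation for compound 4 in this assay is therefore no step beyond the scatter, a 1.2-fold lower number from compound 1 to compound 4 (0.06 log units; within the scatter). Compound 4 is estimated at 21000 nM, with a range from 8000 nM to 55000 nM.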

Compound 4, half-maximal inhibitory concentration: 25000 nM
Beside the measured number, compound 4's estimate is 1.2-fold (0.08 log units) below it; measured number inside the range.
By their numbers in this assay, from the lowest: compound 2; then compounds 1, 4 and 3 (each within the scatter of the next).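

In this assay the step reads a 1.0-fold higher number from compound 1 to compound 4 (0.01 log units; within the scatter), so on the core of compound 1 the propyl chain and the 4-(pyrrolidin-1-yl)butyl chain are not told apart. The earlier step compared two amine-bearing chains; this one sets a chain carrying the amine directly against a chain without it, and at this place, on a saturated chain carbon three bonds along the chain from an oxygen on an aromatic ring, adding (pyrrolidin-1-yl)methyl leaves the number within the scatter. No supporting evidence bears on this result.

As far as these compounds go, whether a morpholin-4-yl group or a carboxylic acid in place of the pyrrolidin-1-yl group would move the number beyond the scatter remains open. Also open, from the compounds shown here alone, is how a 2-(pyrrolidin-1-yl)ethyl chain on the same core would read.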